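Shortening the Amide Side Chain on a Second Core

This account rests on a few compounds, and the source may have more. Where it says the series, first, only, none or still open, it means among the compounds named here.

Compound 1 `O=C(NCCCCc1ccccc1)n1cc(-c2ccccc2)oc1=O` gives 90 nM. Compound 2 `CCCCCNC(=O)n1cc(-c2ccccc2)oc1=O` gives 39 nM. Compound 3 `CN1CCC(c2cc(-c3cn(C(=O)NCCCCc4ccccc4)c(=O)o3)ccc2F)CC1` gives 341 nM.

All three measured compounds were tested in an assay on isolated protein for inhibition of acid ceramidase (Homo sapiens), read by LC-MS, with a stated time of 1 h; a higher number here means a weaker inhibitor, a lower number a stronger inhibitor. Compound 1 and compound 2 share a core and differ in a single place: methyl in place of phenyl on a saturated chain carbon, four bonds along the chain from an amide-type nitrogen. This change produced a 2.3-fold lower number from compound 1 to compound 2 (0.36 log units; beyond the scatter), a modest step that lies beyond the usual scatter.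

Compound 3 is built on a different core; the difference between the core of compound 1 and the core of compound 3 is not broken down here. Compound 3 gives the highest number of the three, and its steps to compound 1 and to compound 2 are both beyond the scatter, so it is the weakest inhibitor among the measured set in this assay .

Compound 4 `CCCCCNC(=O)n1cc(-c2ccc(F)c(C3CCN(C)CC3)c2)oc1=O` has not yet been measured. It stands to compound 3 as compound 2 stands to compound 1: methyl in place of phenyl on a saturated chain carbon, four bonds along the chain from an amide-type nitrogen. The place of the change is described in the same words for both pairs, so this is the same change made on a second core.

Compound 4 is expected to give 150 nM in this assay , with a range from 60 nM to 400 nM. The expectation rests on compound 1 and compound 2 because the same change there produced a 2.3-fold lower number from compound 1 to compound 2 (0.36 log units; beyond the scatter). Within the data shown here, the estimated step from compound 3 to compound 4 is a 2.3-fold lower number from compound 3 to compound 4 (0.36 log units; beyond the scatter), with a wider range than the single earlier step, since only one example of this change is measured and it is on a different core.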

Compound 4, half-maximal inhibitory concentration: 1920 nM
The estimate for compound 4 lay 13-fold (1.11 log units) below the measured number; measured number outside the range, above it.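

In this assay, exchanging phenyl for methyl on the saturated chain carbon, four bonds along the chain from the amide-type nitrogen, gave a 5.6-fold higher number from compound 3 to compound 4 (0.75 log units; beyond the scatter). Among these compounds, on the core of compound 3 the number therefore rose with this change, whereas on the core of compound 1 it fell, so the direction of the step did not carry from one core to the other, and the two steps differ by more than scatter alone would give: the same change on two cores in this assay, a 2.3-fold lower number (0.36 log units; beyond the scatter) from compound 1 to compound 2 and a 5.6-fold higher number (0.75 log units; beyond the scatter) from compound 3 to compound 4, 13-fold (1.11 log units) apart, beyond the scatter of two such steps This shows that, within these two pairs, the result of the change depends on the core it is made on, but it does not show which feature of the core is responsible, and with only two pairs it sets no general rule for the series.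

On these data alone, it remains open which of the features that set the core of compound 3 apart from the core of compound 1 goes with the reversal, and whether either one alone would be enough. Also open, as far as these compounds go, is how the two cores would respond to other chains, such as a longer chain or one ending in an amine or a carboxylic acid, and whether their steps would again part in direction.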